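A few compounds are considered here, and "the series" means these few. Any claim that something is new, unique, unknown or untested is made for them only; others in the source may bear on it.

Measured so far:
compound 1 `COc1ccc(C2C(C#N)=C(N)N(c3cc(OC)c(OC)c(OC)c3)C3=C2C(=O)CC(C)(C)C3)cc1` — 1%
compound 2 `COc1cc(N2C(N)=C(C#N)C(c3c(OC)ccc4ccccc34)C3=C2CC(C)(C)CC3=O)cc(OC)c1OC` — 5%
compound 3 `COc1ccccc1C1C(C#N)=C(N)N(c2cc(OC)c(OC)c(OC)c2)C2=C1C(=O)CC(C)(C)C2` — 65%

In a functional assay on Ehrlich cells (Mus musculus) for cytotoxicity, tested at 25 ug/mL (on this read-out lower numbers stand for a weaker effect and higher numbers for a stronger effect at the one concentration tested), compound 3 gives the highest of the three numbers. The two steps that lead to it, a number 64 percentage points higher from compound 1 to compound 3 (beyond the scatter) and a number 60 percentage points higher from compound 2 to compound 3 (beyond the scatter), are both large, whereas a number 4 percentage points higher from compound 1 to compound 2 (within the scatter). All three differ only in the group on the saturated ring carbon, so this one position decides the whole spread seen so far.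

Compound 4 `COc1cc(N2C(N)=C(C#N)C(c3cccs3)C3=C2CC(C)(C)CC3=O)cc(OC)c1OC` changes that same position: thiophen-2-yl in place of 2-methoxyphenyl on a saturated ring carbon. Among the compounds with values here, no measured step involves thiophen-2-yl, so the direction rests only on the fact that two of three groups tried there gave weak numbers and compound 3 alone gave a strong one. A drop back toward the weak pair is therefore expected, a number 40 percentage points lower from compound 3 to compound 4 (beyond the scatter). Compound 4 is estimated at 25%, with a range from 2% to 60%.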

Compound 4, a percentage reported as activity, at one concentration (the size of the read-out at that concentration, not a potency): 10%
Beside the measured number, compound 4's estimate is 15 percentage points above it; low and high end bracket the measured number.
By their numbers in this assay, from the lowest: compounds 1, 2 and 4 (each within the scatter of the next); then compound 3.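

In this assay thiophen-2-yl gives a number 55 percentage points lower from compound 3 to compound 4 (beyond the scatter), so a third, quite different group fails to keep the strong number of compound 3. Against the two weak compounds, the steps are a number 5 percentage points higher from compound 2 to compound 4 (within the scatter) and a number 9 percentage points higher from compound 1 to compound 4 (within the scatter), which leaves 2-methoxyphenyl alone among the four groups at this carbon. Nothing at hand explains why this group stands apart. Still open, going by these compounds, is how plain phenyl, 3-methoxyphenyl or 2-hydroxyphenyl would read here. Those groups would show whether the methoxy group and its place on the phenyl ring matter.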